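The source may report more compounds than this note shows. Statements on the series, on what has been measured and on what is new or still open speak of the compounds shown alone.

Working notes on the series: in a functional assay on Ehrlich cells (Mus musculus) for cytotoxicity, read by LDH release, with a stated time of 48 h (a higher number here means a weaker inhibitor, a lower number a stronger inhibitor), compound 1 `COc1ccc(C(=O)c2cc(C)ccc2OCC(=O)NNC(=O)c2cc3ccccc3oc2=O)cc1` gives 41200 nM and compound 2 `Cc1ccc(OCC(=O)NNC(=O)c2cc3ccccc3oc2=O)c(C(=O)c2cccc(Br)c2)c1` gives 68100 nM. For the measured compounds named here, these are the only two measurements so far, and compound 2 stands within the scatter of compound 1, so neither can be ranked ahead of the other.

The next compound is compound 3 `Cc1ccc(OCC(=O)NNC(=O)c2cc3ccccc3oc2=O)c(C(=O)c2ccc(Br)cc2)c1`, which has the same atoms as compound 2, joined differently: 4-bromophenyl in place of 3-bromophenyl on a carbonyl carbon. In words, this places 4-bromophenyl in place of 3-bromophenyl on a carbonyl carbon.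

Going by the values given here, only one measured step bears on this change, and only indirectly: a 1.7-fold higher number from compound 1 to compound 2 (0.22 log units; within the scatter). Among the compounds with values here, that step exchanged 3-bromophenyl for 4-methoxyphenyl on a carbonyl carbon, so no measured pair isolates the present change. With so little evidence, no step beyond the scatter is expected in this assay, and neither direction is favoured.

The expected change is a 1.2-fold lower number from compound 2 to compound 3 (0.09 log units; within the scatter), which is not expected to exceed the scatter. For compound 3, the estimated value is 55000 nM, with an expected range of 25000 nM to 110000 nM.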

Compound 3, half-maximal inhibitory concentration: 89000 nM
Compound 3: the middle estimate sits 1.6-fold (0.21 log units) below what was measured, and the stated range covers the measured number.
By their numbers in this assay, from the lowest: compounds 1, 2 and 3 (each within the scatter of the next, the first and the last beyond it).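

Moving the bromine from 3-bromophenyl to 4-bromophenyl on a carbonyl carbon gives, in this assay, a 1.3-fold higher number from compound 2 to compound 3 (0.12 log units; within the scatter), so this pair with identical atoms shows no readable dependence on which of these two bromophenyl groups is present. Bromo in place of methoxy on an aromatic carbon gives a 2.2-fold higher number from compound 1 to compound 3 (0.33 log units; beyond the scatter), the first step in the series beyond the scatter, though only a modest one, and it is seen with 4-bromophenyl, while compound 2 with 3-bromophenyl stays within the scatter of compound 1. No supporting data bear on why either step has this size.

From the compounds shown here alone, it remains open whether an amine or a carboxylic acid in place of the bromo on this aromatic carbon would shift the number clearly. Compound 1 gives 41200 nM, and whether any such group could bring the number lower than this compound does is open as well. Also open, going by these compounds, is how far the number depends on the rest of the shared core, for example with a longer chain in the link to the carbonyl-bearing part or with an ethyl group in place of the methyl.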